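Aryl amide in place of aryl urea-type carbonyl

A few compounds are considered here, and "the series" means these few. Any claim that something is new, unique, unknown or untested is made for them only; others in the source may bear on it.

- compound 1 `CN1CCC(C(=O)N2Cc3c(NC(=O)C4CC4)n[nH]c3C2(C)C)CC1`: 1420 nM
- compound 2 `CN1CCC(C(=O)N2Cc3c(NC(=O)c4ccc5ccccc5c4)n[nH]c3C2(C)C)CC1`: 270 nM
- compound 3 `CN1CCC(C(=O)N2Cc3c(NC(=O)Nc4cccc(F)c4)n[nH]c3C2(C)C)CC1`: 350 nM

All three compounds were tested in a functional assay on A2780 cells (Homo sapiens) for antiproliferative activity, read by fluorescence, with a stated time of 72 h; on this read-out lower numbers stand for stronger inhibition and higher numbers for weaker inhibition. Compound 3 stands well apart from one of the others, with a 4.1-fold lower number from compound 1 to compound 3 (0.61 log units; beyond the scatter), and has no separation from the other, with a 1.3-fold higher number from compound 2 to compound 3 (0.11 log units; within the scatter).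

Compound 4 `CN1CCC(C(=O)N2Cc3c(NC(=O)c4cccc(F)c4)n[nH]c3C2(C)C)CC1` has not yet been measured. It carries 3-fluorophenyl in place of (3-fluorophenyl)amino on a carbonyl carbon.

Among the compounds with values here, three measured steps bear on this change. Replacing cyclopropyl with naphthalen-2-yl gave a 5.3-fold lower number from compound 1 to compound 2 (0.72 log units; beyond the scatter), a modest step of similar size to the one above from cyclopropyl to (3-fluorophenyl)amino. Compound 2 is the closest guide, since it also has an aromatic ring on the carbonyl carbon and its value of 270 nM lies within the scatter of that of compound 3. No step beyond the scatter is therefore expected in this assay. The expected change is a 1.1-fold higher number from compound 3 to compound 4 (0.06 log units; within the scatter).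

For compound 4 the estimated value is 400 nM, with an expected range from 170 nM to 900 nM.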

Compound 4, half-maximal inhibitory concentration: 200 nM
For compound 4 the middle estimate is 2.0-fold (0.30 log units) above the measured one; the measured number falls inside the stated range.
By their numbers in this assay, from the lowest: compounds 4, 2 and 3 (each within the scatter of the next); then compound 1.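

In this assay, 3-fluorophenyl in place of (3-fluorophenyl)amino on a carbonyl carbon gives a 1.8-fold lower number from compound 3 to compound 4 (0.24 log units; within the scatter), so the hydrogen-bond donor counted in the leaving group is not required for activity in this pair. The single fluorinated ring also stands level with the larger naphthalen-2-yl, at a 1.4-fold lower number from compound 2 to compound 4 (0.13 log units; within the scatter), while the separation from the cyclopropyl amide, a 7.1-fold lower number from compound 1 to compound 4 (0.85 log units; beyond the scatter), shows that compounds 2, 3 and 4, each with an aromatic ring in this part of the molecule, all stand clear of compound 1. No measurement at hand accounts for these results.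

On these data alone, what an unsubstituted phenyl, a methoxyphenyl or a pyridine would give on this carbonyl carbon stays open, and with it the contribution of the fluorine. Also open, as far as these compounds go, is how a longer alkyl chain would compare with cyclopropyl.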